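Swapping the distal phenyl for methylpyrazole on a shared core

The source may report more compounds than this note shows. Statements on the series, on what has been measured and on what is new or still open speak of the compounds shown alone.

Compound 1 `CNC(=O)N1CCCc2ccc(NC(=O)c3ccc(-c4ccccc4)cc3)cc21`: 19.7%
Compound 2 `CNC(=O)N1CCCc2ccc(NC(=O)c3cccc(-c4cnn(C)c4)c3)cc21`: 71.2%

Both compounds were tested in a functional assay on MV4-11 cells (Homo sapiens) for antiproliferative activity, with a stated time of 6 days, tested at 1.56 uM; a lower number here means a weaker effect, a higher number a stronger effect of the compound at the concentration tested. Compound 1 stands lowest of the two numbers; its nearest neighbour, compound 2, gives a higher number, beyond the scatter. Compound 1 and compound 2 differ in more than one place, so their two values show only that much.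

Compound 3 `CNC(=O)N1CCCc2ccc(NC(=O)c3ccc(-c4cnn(C)c4)cc3)cc21` has not been measured. It differs from compound 1 by a single change: 1-methyl-1H-pyrazol-4-yl in place of phenyl on an aromatic carbon. The change sits on an aromatic carbon of a six-membered aromatic ring of carbon only, para to a large group. Within the data shown here, no measured pair shows the same change alone. The account expects a sizeable rise in this assay from compound 1 to compound 3, since compound 2, which also carries 1-methyl-1H-pyrazol-4-yl, gives 71.2%. Compound 3 is estimated at 50%, within 22% to 78%, an expected step of a number 30.3 percentage points higher from compound 1 to compound 3 (beyond the scatter).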

Compound 3, a percentage reported as inhibition, at one concentration (the size of the read-out at that concentration, not a potency): 77.4%
Compound 3: the middle estimate sits 27.4 percentage points below what was measured; measured number inside the range.
By their numbers in this assay, from the lowest: compound 1; then compounds 2 and 3 (each within the scatter of the next).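

In this assay, 1-methyl-1H-pyrazol-4-yl in place of phenyl on an aromatic carbon, para to a large group, gives a large rise a number 57.7 percentage points higher from compound 1 to compound 3 (beyond the scatter) with the rest of the molecule unchanged. Among these compounds, this is the first view of the change on its own: the earlier pair differed in more than one place and could not separate it from the other differences. The step comes with no change in heavy-atom count, as the entering and leaving groups each hold 6 heavy atoms, though the entering group brings a five-membered aromatic ring with 2 hetero atoms; nothing at hand explains the size of the rise.

Going by these compounds, whether a pyrazole without the methyl, a pyridine or a morpholine would behave alike at this position remains open. So does whether the same swap would give a similar step on another core.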